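Flavonol amide series: ring swap at the carbonyl carbon

The compounds below may be only part of what the source reports. "The series", "measured", "known", "first", "only" and "open" are said of these compounds alone.

Three members of the series have been run in a functional assay on HepG2 cells (Homo sapiens) for antiproliferative activity, read by CCK-8 assay, with a stated time of 72 h; on this read-out lower numbers stand for stronger inhibition and higher numbers for weaker inhibition. Compound 1 `Cc1cccc(C(=O)Nc2cccc(-c3oc4cc(-c5ccc(F)cc5)ccc4c(=O)c3O)c2)c1` gives 13500 nM and stands lowest of the three. Compound 2 `COc1ccc(C(=O)Nc2cccc(-c3oc4cc(-c5ccc(F)cc5)ccc4c(=O)c3O)c2)c(F)c1` gives 45300 nM, and compound 3 `COc1cc(OC)cc(C(=O)Nc2cccc(-c3oc4cc(-c5ccc(F)cc5)ccc4c(=O)c3O)c2)c1` gives 23500 nM. Both changes so far sit on the carbonyl carbon: a 3.4-fold higher number from compound 1 to compound 2 (0.53 log units; beyond the scatter), and a 1.7-fold higher number from compound 1 to compound 3 (0.24 log units; within the scatter). Between the two substituted rings the gap is small, a 1.9-fold lower number from compound 2 to compound 3 (0.29 log units; within the scatter).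

Compound 4 `O=C(Nc1cccc(-c2oc3cc(-c4ccc(F)cc4)ccc3c(=O)c2O)c1)c1cnc(Cl)nc1Cl` is not yet measured. It differs from compound 1 as follows: 2,4-dichloropyrimidin-5-yl in place of 3-methylphenyl on a carbonyl carbon. The steps from compound 1 to compound 2 and from compound 1 to compound 3 bear on this, since each replaces the 3-methylphenyl on the same carbonyl carbon; one moved the number beyond the scatter upward, the other stayed within it. Neither introduces a ring with hetero atoms or chlorine, so the present change is not covered directly. The expectation is therefore a small step, likely toward a higher number, with wide uncertainty: compound 4 is expected at 20000 nM (range 7000 nM to 60000 nM), which means an estimated step of a 1.5-fold higher number from compound 1 to compound 4 (0.17 log units; within the scatter).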

Compound 4, half-maximal inhibitory concentration: > 100000 nM
Compound 4: no number, only a limit; the forecaster's own chance of this, stated with the estimate: 10%; at least 5.0-fold (0.69 log units) between middle value and limit.
By their numbers in this assay, from the lowest: compounds 1, 3 and 2 (each within the scatter of the next, the first and the last beyond it). At a limit, above all of these: compound 4.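

In this assay, among these compounds, compound 4 gives > 100000 nM, which is a limit and not a number, and it is the only such reading in this set: the limit of > 100000 nM in this assay, at which 1 of the 4 values shown sits. Among the compounds shown here, the carbonyl carbon position therefore does not accept every six-membered aromatic ring: the 2,4-dichloropyrimidin-5-yl group gives an at least 7.4-fold higher number from compound 1 to compound 4 (0.86 log units; beyond the scatter), and it also separates from both other rings, with an at least 4.2-fold higher number from compound 3 to compound 4 (0.62 log units; beyond the scatter) and an at least 2.2-fold higher number from compound 2 to compound 4 (0.34 log units; beyond the scatter), so all three steps lie beyond the scatter, whereas the earlier compounds carry rings of carbon only. This change brings in ring nitrogen and chlorine together, the data do not separate the two, and the limit leaves the full size of each step unknown.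

Open, on these data alone, is whether a plain pyrimidin-5-yl group without chlorine, or a 2,4-dichlorophenyl group with chlorine but no ring nitrogen, would read near compound 1 at 13500 nM. Also open, as far as these compounds go, is how a ring carrying an amine or a carboxylic acid would read at this same carbonyl carbon.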